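This account rests on a few compounds, and the source may have more. Where it says the series, first, only, none or still open, it means among the compounds named here.

Measured compounds in an assay on membranes from Cerebral cortex for displacement of a labelled ligand from Neuronal acetylcholine receptor; alpha4/beta2 (Rattus norvegicus); a lower number here means a stronger inhibitor, a higher number a weaker inhibitor:
compound 1 `O=C(Nc1cccc(F)c1)c1cncc(N2CC3CC(C2)N3)c1`, 0.044 nM
compound 2 `O=C(Nc1ccc(F)cc1F)c1cncc(N2CC3CC(C2)N3)c1`, 0.051 nM
compound 3 `O=C(Nc1ccc(Cl)cc1)c1cncc(N2CC3CC(C2)N3)c1`, 0.404 nM

Compound 3 has the highest number of the three; its steps from compound 1 and compound 2 are both beyond the scatter, a 9.2-fold higher number from compound 1 to compound 3 (0.96 log units; beyond the scatter) and a 7.9-fold higher number from compound 2 to compound 3 (0.90 log units; beyond the scatter), while a 1.2-fold higher number from compound 1 to compound 2 (0.06 log units; within the scatter) lies within it. Compound 4 `COc1cccc(NC(=O)c2cncc(N3CC4CC(C3)N4)c2)c1` is reached from compound 3 by 3-methoxyphenyl in place of 4-chlorophenyl on an amide-type nitrogen. For the measured compounds named here, no measured step involves a methoxy group, so the change is only partly covered: both steps that raised the number ended in the 4-chlorophenyl of compound 3, and compound 4 instead carries a 3-methoxyphenyl, as compound 1 carries a 3-fluorophenyl. A lower number is therefore expected for compound 4, estimated as a 3.4-fold lower number from compound 3 to compound 4 (0.53 log units; beyond the scatter), though smaller than the reverse of those steps given the unknown group. Compound 4 is estimated at 0.12 nM, with a range of 0.03 nM to 0.5 nM.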

Compound 4, inhibition constant: 0.56 nM
For compound 4 the middle estimate is 4.7-fold (0.67 log units) below the measured one; measured number outside the range, above it.
By their numbers in this assay, from the lowest: compounds 1 and 2 (each within the scatter of the next); then compounds 3 and 4 (each within the scatter of the next).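

The 3-methoxyphenyl does not track the 3-fluorophenyl on the amide-type nitrogen: methoxy in place of fluoro on the aromatic carbon gives a large rise (a 13-fold higher number from compound 1 to compound 4 (1.10 log units; beyond the scatter)). The gap from the 2,4-difluorophenyl is similar (an 11-fold higher number from compound 2 to compound 4 (1.04 log units; beyond the scatter)), whereas the 4-chlorophenyl cannot be told apart from the 3-methoxyphenyl (a 1.4-fold higher number from compound 3 to compound 4 (0.14 log units; within the scatter)). No available data explain these differences.

Open, as far as these compounds go, is whether a hydroxyl, methyl or ethoxy group in place of the methoxy would sit with compound 1 or with compound 4. Also open, from the compounds shown here alone, is how a 3-chlorophenyl would compare with the 3-fluorophenyl.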